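A few compounds are considered here, and "the series" means these few. Any claim that something is new, unique, unknown or untested is made for them only; others in the source may bear on it.

Measured so far in a functional assay on A549 cells (Homo sapiens) for inhibition, read by MTT assay, with a stated time of 72 h; a higher number here means a weaker inhibitor, a lower number a stronger inhibitor:
- compound 1 `C/C=C\C(=O)Nc1cc(Nc2nc3c(c(-c4cn(C)c5ccccc45)n2)CS(=O)(=O)CC3)c(OC)cc1N(C)CCN(C)C`: 4260 nM
- compound 2 `CCC/C=C\C(=O)Nc1cc(Nc2nc3c(c(-c4cn(C)c5ccccc45)n2)CS(=O)(=O)CC3)c(OC)cc1N(C)CCN(C)C`: 57 nM

Of these two numbers, compound 1 holds the higher, at 4260 nM, so it is the weaker inhibitor in this assay. The next compound to be read is compound 3 `C/C=C\C(=O)Nc1cc(Nc2nc3c(c(-c4cn(C)c5ccc(F)cc45)n2)CS(=O)(=O)CC3)c(OC)cc1N(C)CCN(C)C`, still unmeasured. Its difference from compound 1 is fluoro in place of hydrogen on an aromatic carbon, turning 1-methyl-1H-indol-3-yl into 5-fluoro-1-methyl-1H-indol-3-yl.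

Among the compounds with values here, only one measured step is available, a 75-fold lower number from compound 1 to compound 2 (1.87 log units; beyond the scatter), which is large and beyond the scatter. It bears on this change only indirectly, since it records ethyl in place of hydrogen on a saturated chain carbon, not a change on an aromatic carbon. Within the data shown here, no measured step covers fluoro at this place, so neither its size nor its direction can be carried over. It does show that a single change moved the number a long way in this pair, which argues for a wide range. No shift beyond the scatter is expected in this assay, and the estimated step is a 1.4-fold lower number from compound 1 to compound 3 (0.15 log units; within the scatter). For compound 3 the expected value is 3000 nM, with an estimated range of 700 nM to 9000 nM.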

Compound 3, half-maximal inhibitory concentration: 3990 nM
For compound 3 the middle estimate is 1.3-fold (0.12 log units) below the measured one; low and high end bracket the measured number.
By their numbers in this assay, from the lowest: compound 2; then compounds 3 and 1 (each within the scatter of the next).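

In this assay, within the data shown here, the first reading at this place on the indole part of the series is a flat one: fluoro in place of hydrogen on an aromatic carbon, turning 1-methyl-1H-indol-3-yl into 5-fluoro-1-methyl-1H-indol-3-yl, gives no shift beyond the scatter (a 1.1-fold lower number from compound 1 to compound 3 (0.03 log units; within the scatter)). Among these compounds, the only earlier step lay on the chain at the double bond (a 75-fold lower number from compound 1 to compound 2 (1.87 log units; beyond the scatter)), so the series now holds one single change with a large step and one with none, and the size of the chain step does not carry over to this aromatic carbon. Nothing available bears on the reason for this outcome.

Going by these compounds, this single atom is all that has been read at this aromatic carbon, so it remains open whether chloro, methoxy, an amine or a carboxylic acid at the same place would also stay within the scatter of compound 1. It also remains open whether fluoro at this place would read the same when combined with the longer chain of compound 2, since that pairing is absent from the compounds shown.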